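Pyridinyl in Place of Ethyl on the Piperazine Ring

This account rests on a few compounds, and the source may have more. Where it says the series, first, only, none or still open, it means among the compounds named here.

In a functional assay on DU-145 cells (Homo sapiens) for antiproliferative activity, read by MTT assay, with a stated time of 72 h (on this read-out lower numbers stand for stronger inhibition and higher numbers for weaker inhibition), compound 2 `CCN1CCN(CCCOc2cc3ncnc(Nc4ccc(C#N)cc4)c3cc2OC)CC1` gives 34400 nM. Compound 1 `CCOC(=O)C1CCN(CCCOc2cc3ncnc(Nc4ccc(C#N)cc4)c3cc2OC)CC1` gives 52300 nM in this assay, and the two numbers sit within the scatter of each other. Among the compounds with values here, the only measured step, a 1.5-fold lower number from compound 1 to compound 2 (0.18 log units; within the scatter), swapped the whole ring on the chain and stayed within the scatter. Compound 3 `COc1cc2c(Nc3ccc(C#N)cc3)ncnc2cc1OCCCN1CCN(c2ccncc2)CC1` differs from compound 2 by pyridin-4-yl in place of ethyl on an amine nitrogen in a ring. Within the data shown here, no measured step touches that position, so the expected step of a 1.1-fold lower number from compound 2 to compound 3 (0.06 log units; within the scatter) is none beyond the scatter. Compound 3 is therefore estimated at 30000 nM, between 8000 nM and 110000 nM.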

Compound 3, half-maximal inhibitory concentration: 22900 nM
For compound 3 the middle estimate is 1.3-fold (0.12 log units) above the measured one; low and high end bracket the measured number.
By their numbers in this assay, from the lowest: compounds 3, 2 and 1 (each within the scatter of the next, the first and the last beyond it).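

Putting pyridin-4-yl in place of ethyl on the amine nitrogen adds a ring and a hydrogen-bond acceptor at this position, yet this assay shows only a 1.5-fold lower number from compound 2 to compound 3 (0.18 log units; within the scatter). Within the data shown here, replacing 4-(ethoxycarbonyl)piperidin-1-yl with 4-(pyridin-4-yl)piperazin-1-yl gives the first step beyond the scatter, though a modest one: a 2.3-fold lower number from compound 1 to compound 3 (0.36 log units; beyond the scatter). No measurement here explains either step. From the compounds shown here alone, whether a phenyl ring, a pyridin-3-yl ring or an acetyl group on this nitrogen would give a larger step remains open.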